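Adding a Methyl Beside the Hydroxy of Compound 2

The source may report more compounds than this note shows. Statements on the series, on what has been measured and on what is new or still open speak of the compounds shown alone.

Compound 1 `C[C@@H]1CN(S(=O)(=O)C[C@]23CC[C@H](CC2=O)C3(C)C)CCN1c1ccc(C(F)(F)F)cn1` gives 501 nM in a functional assay on CHO-K1 cells for antagonist activity at C-X-C chemokine receptor type 3 (Homo sapiens), read by FLIPR and calcium flux; a higher number here means a weaker inhibitor, a lower number a stronger inhibitor. Compound 2 `CC1(C)[C@@H]2CC[C@@]1(CS(=O)(=O)N1CCN(c3ccc(C(F)(F)F)cn3)CC1)C(O)C2` gives 158 nM. Compound 3 `CC1(C)[C@@H]2CC[C@@]1(CS(=O)(=O)N1CCN(c3ccc(C(F)(F)F)cn3)CC1)C(F)C2` gives 794 nM.

Compound 2 carries the lowest number of the three; compound 1 lies higher and compound 3 higher still. Among the compounds with values here, the only single-site step in this set, a 5.0-fold higher number from compound 2 to compound 3 (0.70 log units; beyond the scatter), concerns fluoro in place of hydroxy and says nothing about an added methyl. Compound 4 `CC1(O)C[C@H]2CC[C@]1(CS(=O)(=O)N1CCN(c3ccc(C(F)(F)F)cn3)CC1)C2(C)C` differs from compound 2 by methyl in place of hydrogen on a saturated ring carbon, while the hydroxy of compound 2 is retained. Within the data shown here, no measured step bears on such a change, so the expectation is a step of about the scatter or none, a 1.3-fold higher number from compound 2 to compound 4 (0.10 log units; within the scatter). Compound 4 is thus estimated at 200 nM, with a range from 70 nM to 600 nM.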

Compound 4, half-maximal inhibitory concentration: 200 nM
Compound 4: middle estimate and measured number agree at the digits printed; low and high end bracket the measured number.
By their numbers in this assay, from the lowest: compounds 2 and 4 (each within the scatter of the next); then compounds 1 and 3 (each within the scatter of the next).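

With the hydroxy retained, methyl in place of hydrogen on this saturated ring carbon gives a 1.3-fold higher number from compound 2 to compound 4 (0.10 log units; within the scatter) in this assay, so this position takes the added methyl with no step beyond the scatter. Within the data shown here, the only earlier step, fluoro in place of hydroxy, gave a 5.0-fold higher number from compound 2 to compound 3 (0.70 log units; beyond the scatter) and did not touch this change. The data offer no explanation for the result.

On these data alone, whether an ethyl group or a longer chain at this carbon would stay as close to compound 2 remains open. So does the effect of an amine in place of the hydroxy.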